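From Methoxy to Propargyloxy: Estimating Compound 4

This account rests on a few compounds, and the source may have more. Where it says the series, first, only, none or still open, it means among the compounds named here.

Three measured compounds share one core and differ only in the aromatic ring that sits on the double-bonded chain. Compound 1 `COc1ccc(C(=O)c2cc(OC)c(OC)c(OC)c2)cc1NC(=O)/C=C/c1cc(OC)c(OC)c(OC)c1` carries a 3,4,5-trimethoxyphenyl there, and in a functional assay on HT-29 cells (Homo sapiens) for cytotoxicity, read by MTT assay, with a stated time of 72 h (a lower number here means a stronger inhibitor, a higher number a weaker inhibitor), compound 1 gives 3100 nM. Compound 2 `COc1ccc(/C=C/C(=O)Nc2cc(C(=O)c3cc(OC)c(OC)c(OC)c3)ccc2OC)cc1` carries a 4-methoxyphenyl, and in this assay compound 2 gives 5010 nM. Compound 3 `COc1cccc(/C=C/C(=O)Nc2cc(C(=O)c3cc(OC)c(OC)c(OC)c3)ccc2OC)c1` carries a 3-methoxyphenyl, and in this assay compound 3 gives 1900 nM, the lowest of the three numbers. The step of a 1.6-fold lower number from compound 1 to compound 3 (0.21 log units; within the scatter) lies within the scatter, as does a 1.6-fold higher number from compound 1 to compound 2 (0.21 log units; within the scatter), whereas a 2.6-fold lower number from compound 2 to compound 3 (0.42 log units; beyond the scatter) is beyond it.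

Compound 4 `C#CCOc1cccc(/C=C/C(=O)Nc2cc(C(=O)c3cc(OC)c(OC)c(OC)c3)ccc2OC)c1` keeps everything of compound 3 and changes one place: ethynyl in place of hydrogen on a saturated chain carbon bound to an oxygen on an aromatic ring, so the methoxy becomes a propargyloxy. Within the data shown here, none of the measured steps tests a change of this kind; all three rearrange methoxy groups on the ring, and the largest of them, a 2.6-fold lower number from compound 2 to compound 3 (0.42 log units; beyond the scatter), is only modest. Among the measured compounds shown here, with no step that bears on it, the expectation is no change beyond the scatter, so compound 4 is estimated at 1900 nM in this assay, with a range of 700 nM to 5000 nM. The expected step is no change at the digits printed from compound 3 to compound 4 (within the scatter).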

Compound 4, half-maximal inhibitory concentration: 7400 nM
Beside the measured number, compound 4's estimate is 3.9-fold (0.59 log units) below it; measured number above the stated range.
By their numbers in this assay, from the lowest: compounds 3, 1, 2 and 4 (each within the scatter of the next, the first and the last beyond it).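

Among these compounds, the methoxy group at this place is not a silent spot: ethynyl in place of hydrogen on the saturated chain carbon gives a 3.9-fold higher number from compound 3 to compound 4 (0.59 log units; beyond the scatter) in this assay and is the first change here made to the group itself rather than to where methoxy groups stand on the ring. The same compound also shows a 2.4-fold higher number from compound 1 to compound 4 (0.38 log units; beyond the scatter) while a 1.5-fold higher number from compound 2 to compound 4 (0.17 log units; within the scatter) stays within the scatter, so the 3-(propargyloxy)phenyl cannot be told apart from the 4-methoxyphenyl. Nothing available explains this weakening.

Whether the triple bond or simply the longer chain on the oxygen accounts for the step remains open, and a propoxy group at this place would separate the two. On these data alone, how a hydroxyl or an amine in place of the methoxy would read in this assay is also open.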